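The source may hold more compounds than are shown below. What is called first, only, known or untested is meant among the compounds shown, and "the series" means these compounds.

Compound 1, `Cc1nc(N2CCC(O)CC2)nc2ccc(NC(=O)COc3ccc(Cl)cc3)cc12`, gives 150 nM in an assay on CHO-K1 cells for displacement of a labelled ligand from melanin-concentrating hormone receptor 1 (Homo sapiens), with a stated time of 2 h; on this read-out higher numbers stand for weaker inhibition and lower numbers for stronger inhibition. Compound 2, `Cc1nc(N2CCN(CC(C)(C)C)CC2)nc2ccc(NC(=O)COc3ccc(Cl)cc3)cc12`, gives 782 nM. Compound 3, `Cc1nc(N2CCN(C3CCCC3)CC2)nc2ccc(NC(=O)COc3ccc(Cl)cc3)cc12`, gives 96 nM.

Compound 1 sits second highest of the three numbers. Its nearest neighbour is compound 3, with a 1.6-fold lower number from compound 1 to compound 3 (0.19 log units; within the scatter), a difference within the scatter. Its furthest neighbour is compound 2, with a 5.2-fold higher number from compound 1 to compound 2 (0.72 log units; beyond the scatter).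

Compound 4, `Cc1nc(N2CCC(NC(=O)C(C)C)CC2)nc2ccc(NC(=O)COc3ccc(Cl)cc3)cc12`, differs from compound 1 in one place: (isopropylcarbonyl)amino in place of hydroxy on a saturated ring carbon. Going by the values given here, no measured step makes this exact exchange. Among the compounds with values here, the steps from compound 1 to compound 2 and to compound 3 each replace the whole 4-hydroxypiperidin-1-yl group, so they show only that changes in this region can shift the number modestly, as in a 5.2-fold higher number from compound 1 to compound 2 (0.72 log units; beyond the scatter), or leave it within the scatter, as in a 1.6-fold lower number from compound 1 to compound 3 (0.19 log units; within the scatter). On that basis a modest step at most is expected from compound 1 to compound 4, with the direction uncertain, and the estimate is a 1.7-fold higher number from compound 1 to compound 4 (0.22 log units; within the scatter). Compound 4 is therefore expected to give about 250 nM, plausibly between 80 nM and 800 nM.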

Compound 4, half-maximal inhibitory concentration: 15 nM
Compound 4: middle estimate off by 17-fold (1.22 log units), on the high side; measured number below the stated range.
By their numbers in this assay, from the lowest: compound 4; then compounds 3 and 1 (each within the scatter of the next); then compound 2.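

In this assay, going by these compounds alone, the earlier steps replaced the whole 4-hydroxypiperidin-1-yl group, whereas this one keeps that six-membered ring and changes only the group on its saturated ring carbon, three ring bonds from the ring nitrogen. That single exchange gives a 10-fold lower number from compound 1 to compound 4 (1.00 log units; beyond the scatter), so this one position can move the number beyond the scatter, and towards stronger inhibition, even though the entering group has 6 heavy atoms in place of 1 and the counts of hydrogen-bond donors and acceptors stay the same. Nothing measured here accounts for the stronger inhibition of compound 4.

The compounds shown leave open which part of the (isopropylcarbonyl)amino group matters, the carbonyl or the isopropyl. A plain amino group, an acetylamino group or a longer acyl chain at this position would help separate the two.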